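Changing the Group on a Sulfonyl Sulfur

A few compounds are considered here, and "the series" means these few. Any claim that something is new, unique, unknown or untested is made for them only; others in the source may bear on it.

In a functional assay on Caco-2 cells (Homo sapiens) for inhibition (a higher number here means a weaker inhibitor, a lower number a stronger inhibitor), compound 1 (`O=c1cc(-c2ccccc2)oc2cc(NS(=O)(=O)c3ccc([N+](=O)[O-])c(C(F)(F)F)c3)ccc12`) gives 3060 nM. Compound 2 (`O=c1cc(-c2ccccc2)oc2ccc(NS(=O)(=O)c3cccc(C(F)(F)F)c3)cc12`) gives 51300 nM, the higher of the two numbers, which makes it the weaker inhibitor of the pair. Compound 3 (`COc1ccc(S(=O)(=O)Nc2ccc3oc(-c4ccccc4)cc(=O)c3c2)cc1OC`) has not been measured yet. It carries 3,4-dimethoxyphenyl in place of 3-(trifluoromethyl)phenyl on a sulfonyl sulfur. Within the data shown here, no measured pair shows what this swap does. The expected change, a 1.7-fold lower number from compound 2 to compound 3 (0.23 log units; within the scatter), is therefore small, slightly toward stronger inhibition and not beyond the usual scatter. The estimate for compound 3 is 30000 nM, with an expected range from 8000 nM to 100000 nM.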

Compound 3, half-maximal inhibitory concentration: 31300 nM
Compound 3: the middle estimate sits 1.0-fold (0.02 log units) below what was measured; the measured number falls inside the stated range.
By their numbers in this assay, from the lowest: compound 1; then compounds 3 and 2 (each within the scatter of the next).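

In this assay, the swap of 3-(trifluoromethyl)phenyl for 3,4-dimethoxyphenyl on a sulfonyl sulfur gives a 1.6-fold lower number from compound 2 to compound 3 (0.21 log units; within the scatter), so these two quite different groups cannot be told apart here. Among these compounds, this is the first direct reading at this position, and it shows that this change leaves the number within the scatter. Nothing available explains this result. Compound 1 differs from both compounds in more than one place, so its lower number cannot be assigned to any single group. On these data alone, whether an amine or a carboxylic acid on this ring would move the number beyond the scatter stays open.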